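The source may report more compounds than this note shows. Statements on the series, on what has been measured and on what is new or still open speak of the compounds shown alone.

Measured compounds:
- compound 1 `CC(Oc1ccc2c(=O)c(-c3ccc(O)cc3)coc2c1)C(=O)O`: 2500 nM
- compound 2 `O=c1c(-c2ccc(O)cc2)coc2cc(OCCCCCCO)ccc12`: 120 nM

In an assay (Cricetulus griseus) for inhibition of aldehyde dehydrogenase, mitochondrial (Homo sapiens) (a higher number here means a weaker inhibitor, a lower number a stronger inhibitor), compound 1 gives 2500 nM and stands highest of the two numbers; its nearest neighbour is compound 2, and the step of a 21-fold lower number from compound 1 to compound 2 (1.32 log units; beyond the scatter) was large, with 6-hydroxyhexyl in place of 1-carboxyethyl on the aromatic oxygen.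

Compound 3 `CCCCCCC(Oc1ccc2c(=O)c(-c3ccc(O)cc3)coc2c1)C(=O)O` differs from compound 1 by pentyl in place of hydrogen on a saturated chain carbon, two bonds along the chain from a carbonyl carbon and an oxygen on an aromatic ring. Among the measured compounds shown here, no measured step covers this exact change. For the measured compounds named here, the one step available, a 21-fold lower number from compound 1 to compound 2 (1.32 log units; beyond the scatter), reworked the same side chain and lowered the number markedly, but it also removed the acid, which compound 3 keeps. The only ground for an expectation is that a longer chain at this position was tolerated well in compound 2, so a moderate lowering beyond the scatter is expected, though a smaller one than the measured step. For compound 3 the estimated value is 900 nM, within 250 nM to 3000 nM. Relative to compound 1 the expected step reads a 2.8-fold lower number from compound 1 to compound 3 (0.44 log units; beyond the scatter).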

Compound 3, half-maximal inhibitory concentration: 2000 nM
Estimate against measurement, compound 3: 2.2-fold (0.35 log units) below, and the stated range covers the measured number.
By their numbers in this assay, from the lowest: compound 2; then compounds 3 and 1 (each within the scatter of the next).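

In this assay the step for pentyl in place of hydrogen on a saturated chain carbon, two bonds along the chain from a carbonyl carbon and an oxygen on an aromatic ring, reads a 1.3-fold lower number from compound 1 to compound 3 (0.10 log units; within the scatter) and so stays inside the usual scatter. With the carboxylic acid kept, the added chain alone therefore does not reproduce a 21-fold lower number from compound 1 to compound 2 (1.32 log units; beyond the scatter) as seen for 6-hydroxyhexyl in place of 1-carboxyethyl. No measurement at hand accounts for either step.

Going by these compounds, whether a plain hexyl chain on the aromatic oxygen, with neither carboxylic acid nor hydroxyl, would read like compound 2 or like compounds 1 and 3 stays open. Also open, on these data alone, is how an amine in place of the carboxylic acid would read on this side chain.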